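Swapping the Sulfur-Linked Group on a Shared Core

The compounds below may be only part of what the source reports. "The series", "measured", "known", "first", "only" and "open" are said of these compounds alone.

Three compounds share one core and differ only in the group on a saturated chain carbon bound to a sulfur:

Compound 1, `Cc1cc(Nc2cc(-c3ccccc3)[nH]n2)n2nc(SCCCc3ccccc3)nc2n1`: in a functional assay on MGC-803 cells (Homo sapiens) for inhibition, read by MTT assay, with a stated time of 72 h (a lower number here means a stronger inhibitor, a higher number a weaker inhibitor), compound 1 gives 6510 nM
Compound 2, `Cc1cc(Nc2cc(-c3ccccc3)[nH]n2)n2nc(SCc3cccc4ccccc34)nc2n1`: in this assay compound 2 gives 3120 nM
Compound 3, `Cc1cc(Nc2cc(-c3ccccc3)[nH]n2)n2nc(SCC3CCCCC3)nc2n1`: in this assay compound 3 gives 12600 nM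

Compound 3 has the highest number of the three. Its nearest neighbour is compound 1, a gap within the scatter; its furthest is compound 2, a gap beyond the scatter. Compound 4, `Cc1cc(Nc2cc(-c3ccccc3)[nH]n2)n2nc(SCC(=O)c3ccccc3)nc2n1`, has not yet been measured. Relative to compound 3 the change is benzoyl in place of cyclohexyl on a saturated chain carbon bound to a sulfur.

Among the compounds with values here, two measured steps bear on this change, both ending at compound 3: a 1.9-fold higher number from compound 1 to compound 3 (0.29 log units; within the scatter) and a 4.0-fold higher number from compound 2 to compound 3 (0.61 log units; beyond the scatter). Read the other way, exchanging the cyclohexyl for a group carrying an aromatic ring went with lower numbers, once within and once beyond the scatter. The benzoyl that enters also carries an aromatic ring, so a modest drop is expected, roughly a 2.5-fold lower number from compound 3 to compound 4 (0.40 log units; beyond the scatter). Compound 4 is therefore estimated at 5000 nM, within a range from 2000 nM to 12500 nM.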

Compound 4, half-maximal inhibitory concentration: 2580 nM
Estimate against measurement, compound 4: 1.9-fold (0.29 log units) above; the range from low to high includes it.
By their numbers in this assay, from the lowest: compounds 4 and 2 (each within the scatter of the next); then compounds 1 and 3 (each within the scatter of the next).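

In this assay, benzoyl in place of cyclohexyl gives a 4.9-fold lower number from compound 3 to compound 4 (0.69 log units; beyond the scatter), so a group with a carbonyl and a hydrogen-bond acceptor is tolerated on this chain carbon and goes with a lower number. Benzoyl in place of phenethyl gives a 2.5-fold lower number from compound 1 to compound 4 (0.40 log units; beyond the scatter), while benzoyl in place of naphthalen-1-yl gives a 1.2-fold lower number from compound 2 to compound 4 (0.08 log units; within the scatter), which places compound 4 level with compound 2 and shows that a larger aromatic group is not needed to reach this level. No measurement shown explains these differences.

Benzoyl differs from cyclohexyl in both its aromatic ring and its carbonyl, so the contribution of each remains unresolved. A benzyl group at this place would separate the two, and a carboxylic acid or an amine on the chain would test other kinds of group.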